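Swapping the ring nitrogen substituent of compound 3 for cyclohexyl

The source may hold more compounds than are shown below. What is called first, only, known or untested is meant among the compounds shown, and "the series" means these compounds.

Compound 1 `CC(C)c1onc(-c2c(Cl)cccc2Cl)c1COc1ccc(-c2nc3ccc(C(=O)O)cc3n2-c2ccc(F)cc2)cc1` gives 32.2 nM in an assay on Huh-7 cells for agonist activity at Bile acid receptor (Homo sapiens), read by a luciferase reporter; on this read-out higher numbers stand for an effect only at larger amounts of compound and lower numbers for an effect already at smaller amounts.
Compound 2 `CC(C)c1onc(-c2c(Cl)cccc2Cl)c1COc1ccc(-c2nc3ccc(C(=O)O)cc3n2C2CCCCCC2)cc1` gives 14.8 nM in this assay.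
Compound 3 `CC(C)c1onc(-c2c(Cl)cccc2Cl)c1COc1ccc(-c2nc3ccc(C(=O)O)cc3n2Cc2ccc(F)cc2)cc1` gives 3.31 nM in this assay.

Compound 3 holds the lowest number of the three; the steps of a 9.7-fold lower number from compound 1 to compound 3 (0.99 log units; beyond the scatter) and a 4.5-fold lower number from compound 2 to compound 3 (0.65 log units; beyond the scatter) both lie beyond the scatter. Compound 4 `CC(C)c1onc(-c2c(Cl)cccc2Cl)c1COc1ccc(-c2nc3ccc(C(=O)O)cc3n2C2CCCCC2)cc1` differs from compound 3 by cyclohexyl in place of 4-fluorobenzyl on an aromatic nitrogen. The most telling comparison is the step of a 4.5-fold lower number from compound 2 to compound 3 (0.65 log units; beyond the scatter), which runs in the opposite direction and exchanges a seven-membered ring for the same 4-fluorobenzyl; the step of a 2.2-fold lower number from compound 1 to compound 2 (0.34 log units; beyond the scatter) shows that a non-aromatic ring gave a somewhat lower number than 4-fluorophenyl. Compound 4 is therefore expected to give a higher number than compound 3, a step of about a 3.6-fold higher number from compound 3 to compound 4 (0.56 log units; beyond the scatter) in this assay. The estimate for compound 4 is 12 nM, with a range from 5 nM to 35 nM.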

Compound 4, half-maximal effective concentration: 4.21 nM
For compound 4 the middle estimate is 2.9-fold (0.45 log units) above the measured one, and the stated range ends above it.
By their numbers in this assay, from the lowest: compounds 3 and 4 (each within the scatter of the next); then compound 2; then compound 1.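

In this assay, cyclohexyl on the aromatic nitrogen stands in for 4-fluorobenzyl with a 1.3-fold higher number from compound 3 to compound 4 (0.10 log units; within the scatter), so among these compounds a low number does not depend on an aromatic ring in this substituent. Ring size does count here, since cyclohexyl in place of cycloheptyl gives a 3.5-fold lower number from compound 2 to compound 4 (0.55 log units; beyond the scatter), and cyclohexyl in place of 4-fluorophenyl gives a 7.6-fold lower number from compound 1 to compound 4 (0.88 log units; beyond the scatter). Nothing available explains these differences. As far as these compounds go, whether a smaller ring such as cyclopentyl or an open chain such as isobutyl would keep the number of compound 4 remains open.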